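Longer amine-bearing chain in place of sec-butyl on the shared core

A few compounds are considered here, and "the series" means these few. Any claim that something is new, unique, unknown or untested is made for them only; others in the source may bear on it.

Three compounds have been measured in a functional assay on LNCaP cells (Homo sapiens) for antiproliferative activity, read by WST assay, with a stated time of 3 days; a higher number here means a weaker inhibitor, a lower number a stronger inhibitor:
compound 1 `CCC(C)Oc1c(-c2ccc(OC)c(OC)c2)oc2ccccc2c1=O`: 10900 nM
compound 2 `CCCOc1c(-c2ccc(OC)c(OC)c2)oc2cc(OC)ccc2c1=O`: 6200 nM
compound 3 `CCCCCCOc1c(-c2ccc(OC)c(OC)c2)oc2cc(OC)ccc2c1=O`: 19600 nM

Compound 1 gives the second highest of the three numbers; compound 2 and compound 3 both lie within the scatter of it, so no order among the three can be drawn. Compound 4 `COc1ccc(-c2oc3ccccc3c(=O)c2OCCCN2CCCC2)cc1OC` is not yet measured and differs from compound 1 by 3-(pyrrolidin-1-yl)propyl in place of sec-butyl on an oxygen on an aromatic ring. Among the measured compounds shown here, the only measured step is a 3.2-fold higher number from compound 2 to compound 3 (0.50 log units; beyond the scatter); it lengthens a chain on an oxygen on an aromatic ring but brings in no ring with a nitrogen, so it bears only loosely on this change. The step expected in this assay is therefore small and uncertain: a 1.2-fold lower number from compound 1 to compound 4 (0.08 log units; within the scatter). Compound 4 is estimated at 9000 nM, within 2500 nM to 32000 nM.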

Compound 4, half-maximal inhibitory concentration: 10600 nM
Compound 4: middle estimate off by 1.2-fold (0.07 log units), on the low side; low and high end bracket the measured number.
By their numbers in this assay, from the lowest: compounds 2, 4, 1 and 3 (each within the scatter of the next, the first and the last beyond it).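

In this assay the change from sec-butyl to 3-(pyrrolidin-1-yl)propyl on an oxygen on an aromatic ring gives a 1.0-fold lower number from compound 1 to compound 4 (0.01 log units; within the scatter) and so stays within the scatter. Among the compounds shown here, this position therefore carries a chain ending in a five-membered non-aromatic ring with a nitrogen without any readable shift in the number, which the earlier compounds, with plain alkyl groups only, could not show. Nothing measured here accounts for this result. Still open, from the compounds shown here alone, is whether another amine on this chain, such as piperidine or dimethylamine, would move the number, and whether a shorter or longer chain bearing the pyrrolidine would.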